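The source may report more compounds than this note shows. Statements on the series, on what has been measured and on what is new or still open speak of the compounds shown alone.

Measured so far in a functional assay on A549 cells (Homo sapiens) for antiproliferative activity, read by MTT assay, with a stated time of 48 h; a lower number here means a stronger inhibitor, a higher number a weaker inhibitor:
Compound 1 `COc1ccc(C(=O)c2ccc(OC)c3c2OC(C)(C)C=C3)c(NC(=O)CO)c1` gives 80 nM
Compound 2 `C=C(c1cc(OC)c(OC)c(OC)c1)c1ccc(OC)cc1NC(=O)CN(C)C` gives 130 nM
Compound 3 `C=C(c1cc(OC)c(OC)c(OC)c1)c1ccc(OC)c(O)c1NC(=O)COC` gives 190 nM

Compound 3 at 190 nM stands within the scatter of compound 2 but is weaker than compound 1 by more than the scatter. Compound 4 `C=C(c1cc(OC)c(OC)c(OC)c1)c1ccc(OC)c(O)c1NC(=O)CN(C)C` differs from compound 3 by dimethylamino in place of methoxy on a saturated chain carbon bound to a carbonyl carbon and nothing else. Within the data shown here, no step between compounds differing in one place has been measured. No step beyond the scatter is expected in this assay. This expectation rests on compound 2, which gives 130 nM with the same dimethylamino, close to compound 3. The expected move is a 1.4-fold lower number from compound 3 to compound 4 (0.13 log units; within the scatter) and stays within the scatter. Compound 4 is estimated at 140 nM with an expected range of 45 nM to 430 nM as its likely span.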

Compound 4, half-maximal inhibitory concentration: 50 nM
Estimate against measurement, compound 4: 2.8-fold (0.45 log units) above; low and high end bracket the measured number.
By their numbers in this assay, from the lowest: compounds 4, 1, 2 and 3 (each within the scatter of the next, the first and the last beyond it).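

Dimethylamino in place of methoxy on a saturated chain carbon bound to a carbonyl carbon brings a 3.8-fold lower number from compound 3 to compound 4 (0.58 log units; beyond the scatter) and is the first change at this place that can be read on its own. Hydroxy in place of hydrogen on an aromatic carbon, with dimethylamino kept on the chain, brings a 2.6-fold lower number from compound 2 to compound 4 (0.41 log units; beyond the scatter) and so each of the two changes, read once, lowers the number. Nothing available here offers an explanation for either step.

From the compounds shown here alone, whether a morpholine, a primary amine or a longer chain carrying the dimethylamino would hold this lower number at the same chain carbon remains open.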